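A few compounds are considered here, and "the series" means these few. Any claim that something is new, unique, unknown or untested is made for them only; others in the source may bear on it.

Measured so far in an assay on isolated protein for displacement of a labelled ligand from metabotropic glutamate receptor 5 (Homo sapiens), with a stated time of 60 min, tested at 1 uM; a lower number here means less inhibition, a higher number more inhibition at the concentration tested (going by the name of the read-out):
- compound 1 `CC1CCN(c2c(S(=O)(=O)c3cc(Cl)cc(Cl)c3)cnc3cc(Cl)ccc23)CC1`: 93%
- compound 2 `CC1CCN(c2c(S(=O)(=O)c3ccc(F)c(F)c3)cnc3cc(F)ccc23)CC1`: 94%
- compound 3 `COc1ccc(S(=O)(=O)c2cnc3cc(Cl)ccc3c2N2CCC(C)CC2)cc1OC`: 93%

Compound 3 gives 93% in this assay, level with compound 1 at the digits shown and, with it, the lowest of the three numbers; compound 2 sits a single point higher, within the scatter. The whole set is thus flat at the top of the read-out.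

The next compound, compound 4 `CC1CCN(c2c(S(=O)(=O)c3ccc(F)c(F)c3)cnc3cc(Cl)ccc23)CC1`, differs from compound 3 at one place: 3,4-difluorophenyl in place of 3,4-dimethoxyphenyl on a sulfonyl sulfur.

For the measured compounds named here, one measured step bears directly on this, the exchange of the aryl group on the sulfonyl sulfur: no change at the digits printed from compound 1 to compound 3 (within the scatter). Compound 2, which carries the same 3,4-difluorophenyl on the sulfonyl sulfur but a different core, gives 94%, and compound 1 gives 93%; these two values show no gap beyond the scatter. Going by the values given here, nothing measured so far suggests the sulfonyl aryl group shifts the number.

The expected step from compound 3 to compound 4 is therefore no change at the digits printed from compound 3 to compound 4 (within the scatter), none beyond the scatter. Compound 4 is estimated at 93%, in the range 86% to 98%.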

Compound 4, a percentage reported as inhibition, at one concentration (the size of the read-out at that concentration, not a potency): 90%
Compound 4: the middle estimate sits 3 percentage points above what was measured; low and high end bracket the measured number.
By their numbers in this assay, from the lowest: compounds 4, 1, 3 and 2 (each within the scatter of the next).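

In this assay, 3,4-difluorophenyl in place of 3,4-dimethoxyphenyl on a sulfonyl sulfur gives a number 3 percentage points lower from compound 3 to compound 4 (within the scatter) and 3,4-difluorophenyl in place of 3,5-dichlorophenyl gives a number 3 percentage points lower from compound 1 to compound 4 (within the scatter) on the same core, so all three aryl groups now compare directly at this position with no step beyond the scatter. The series also gains a reading away from the sulfonyl sulfur: chloro in place of fluoro on an aromatic carbon gives a number 4 percentage points lower from compound 2 to compound 4 (within the scatter) and likewise stays inside the scatter. No measurement bears on the reason for any of these steps.

All values sit near the top of the read-out at a single concentration, so they give no order among these groups. From the compounds shown here alone, whether an amine, a carboxylic acid or a longer alkyl chain in place of the aryl group on the sulfonyl sulfur would hold the inhibition remains open.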